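A Ring Replaces a Straight Chain End

The compounds below may be only part of what the source reports. "The series", "measured", "known", "first", "only" and "open" are said of these compounds alone.

- compound 1 `CC(C)CCCOc1cccc(O)c1C(=O)/C=C/c1ccc(O)cc1`: 3630 nM
- compound 2 `CCCCCCOc1cccc(O)c1C(=O)/C=C/c1ccc(O)cc1`: > 30000 nM

In a functional assay on ACHN cells (Homo sapiens) for antiproliferative activity, read by sulforhodamine B assay (on this read-out higher numbers stand for weaker inhibition of growth and lower numbers for stronger inhibition of growth), compound 2 gives > 30000 nM. That value is a limit of the assay, not a number. Compound 3 `O=C(/C=C/c1ccc(O)cc1)c1c(O)cccc1OCC1CCCC1` alters the chain: cyclopentyl in place of pentyl on a saturated chain carbon bound to an oxygen on an aromatic ring. In words, cyclopentyl stands in place of pentyl on a saturated chain carbon bound to an oxygen on an aromatic ring. Going by the values given here, the one measured step that bears on this is an at least 8.2-fold higher number from compound 1 to compound 2 (0.91 log units; beyond the scatter), where the straight chain of compound 2 gave the higher number. Its size is open-ended, as the limit of > 30000 nM in this assay, at which 1 of the 2 values shown sits, shows. Compound 3 also gives up the straight chain, so a move to a lower number, of similar size, is expected. The expected step is an at least 3.3-fold lower number from compound 2 to compound 3 (0.52 log units; beyond the scatter). For compound 3 the estimate is 9000 nM, with an expected range of 2500 nM to 30000 nM.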

Compound 3, concentration for 50% growth inhibition: 3510 nM
Beside the measured number, compound 3's estimate is 2.6-fold (0.41 log units) above it; the range from low to high includes it.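

In this assay, a ring at the chain end does as well as a branch: cyclopentyl in place of pentyl gives an at least 8.5-fold lower number from compound 2 to compound 3 (0.93 log units; beyond the scatter), and cyclopentyl in place of isopentyl gives a 1.0-fold lower number from compound 1 to compound 3 (0.01 log units; within the scatter). Among these three compounds, only the straight chain of compound 2 stands apart. The first of these steps has no upper bound: the limit of > 30000 nM in this assay, at which 1 of the 3 values shown sits.

As far as these compounds go, whether a smaller ring such as cyclopropyl, a larger one such as cyclohexyl, or a ring carrying an amine would match cyclopentyl stays open. The compounds shown also cannot tell why the straight chain differs.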